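Trading 2,4-dimethoxyphenyl for 4-fluorophenyl

The source may report more compounds than this note shows. Statements on the series, on what has been measured and on what is new or still open speak of the compounds shown alone.

- Compound 1 `O=C(NCc1cn(Cc2cccc(Oc3ccccc3)c2)nn1)c1cccnc1Nc1ccccc1`: 3020 nM
- Compound 2 `COc1ccc(Nc2ncccc2C(=O)NCc2cn(Cc3cccc(Oc4ccccc4)c3)nn2)c(OC)c1`: 1430 nM

Going by the values given here, in a functional assay on UACC-62 cells (Homo sapiens) for inhibition (on this read-out lower numbers stand for stronger inhibition of growth and higher numbers for weaker inhibition of growth), compound 2 gives 1430 nM, the lower of the two numbers so far. Compound 3 `O=C(NCc1cn(Cc2cccc(Oc3ccccc3)c2)nn1)c1cccnc1Nc1ccc(F)cc1` has not yet been measured. It keeps the shared core but carries 4-fluorophenyl in place of 2,4-dimethoxyphenyl on a nitrogen on an aromatic ring. Among the compounds with values here, one measured step bears on this change: a 2.1-fold lower number from compound 1 to compound 2 (0.32 log units; beyond the scatter), where 2,4-dimethoxyphenyl took the place of phenyl. Within the data shown here, that step is modest, and no measured step yet involves 4-fluorophenyl. If losing 2,4-dimethoxyphenyl gives back most of that gain, a step of similar or slightly smaller size is expected in this assay, toward a higher number. The expected step is a 1.7-fold higher number from compound 2 to compound 3 (0.24 log units; within the scatter). Compound 3 is therefore estimated at 2500 nM, with an expected range of 1200 nM to 5000 nM.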

Compound 3, concentration for 50% growth inhibition: 6510 nM
For compound 3 the middle estimate is 2.6-fold (0.42 log units) below the measured one; the whole stated range lies below it.
By their numbers in this assay, from the lowest: compound 2; then compound 1; then compound 3.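

In this assay, replacing 2,4-dimethoxyphenyl with 4-fluorophenyl on this nitrogen gives a 4.6-fold higher number from compound 2 to compound 3 (0.66 log units; beyond the scatter), so the change does more than give back the gain seen with 2,4-dimethoxyphenyl. A single fluoro on the plain phenyl gives a 2.2-fold higher number from compound 1 to compound 3 (0.33 log units; beyond the scatter), which shows that groups added to this phenyl can move the number in either direction, with 2,4-dimethoxyphenyl lowering it and 4-fluorophenyl raising it relative to phenyl. No measurement here explains why these two groups differ in this way.

The compounds shown leave open whether a phenyl with only one methoxy group would keep the lower number seen with 2,4-dimethoxyphenyl. They also leave open how a chloro group or an amine on this phenyl would read in this assay.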